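The source may report more compounds than this note shows. Statements on the series, on what has been measured and on what is new or still open speak of the compounds shown alone.

Measured in a physicochemical assay for acid dissociation, read by spectrophotometry:
- compound 1 `CCOc1cc(CN2CCC(NC(=O)c3ccc(Cl)nc3)CC2)cc(OCC)c1-c1ccc(F)cc1`: 7.8
- compound 2 `CCOc1cc(CN2CCC[C@H](NC(=O)c3cncc(C)c3)CC2)ccc1Cl`: "not determined" (no result reported)

Within the data shown here, compound 1 holds the only number so far, and compound 2 has no result, so nothing can be ranked and no measured step is available. Compound 3 `CCOc1cc(CN2CCC(NC(=O)c3ccc(N)nc3)CC2)cc(OCC)c1-c1ccc(F)cc1` keeps the core of compound 1 and changes one group, 6-chloropyridin-3-yl to 6-aminopyridin-3-yl: amino in place of chloro on an aromatic carbon. Among the measured compounds shown here, the only anchor is compound 1 at 7.8, so this expectation is a cautious one: a small upward shift in this assay, probably no larger than the scatter. The expected change is a number 0.20 log units higher from compound 1 to compound 3 (within the scatter). For compound 3 the estimate is 8, with an expected range from 7.5 to 8.5.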

Compound 3, acid dissociation constant: 7.86
Beside the measured number, compound 3's estimate is 0.14 log units above it; the measured number falls inside the stated range.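

In this assay, putting amino in place of chloro gives a number 0.06 log units higher from compound 1 to compound 3 (within the scatter). Among these compounds, at this place, on an aromatic carbon next to the ring nitrogen, this one exchange therefore cannot be told apart from repeat-measurement noise, which the earlier compounds could not show. No other information here bears on this result. From the compounds shown here alone, whether a methoxy group or a carboxylic acid at the same place would give a clearly different reading remains open. So does whether amino in place of chloro would read the same way on a different core.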